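The compounds below may be only part of what the source reports. "The series", "measured", "known", "first", "only" and "open" are said of these compounds alone.

Measured in a functional assay on MCF7 cells (Homo sapiens) for antiproliferative activity, read by CellTiter-Glo, with a stated time of 5 days; a lower number here means a stronger inhibitor, a higher number a weaker inhibitor:
Compound 1 `CC1=C(c2cccc(O)c2)C(c2ccc(OC[C@H](C)N3CCCCC3)cc2)Oc2ccc(O)cc21`: 0.1 nM
Compound 2 `CC1=C(c2cccc(S(C)(=O)=O)c2)C(c2ccc(OC[C@H](C)N3CC[C@@H](C)C3)cc2)Oc2ccc(O)cc21`: 4.3 nM
Compound 3 `CC1=C(c2cccc(O)c2)C(c2ccc(OC[C@H](C)N3CC[C@@H](C)C3)cc2)Oc2cc(O)ccc21`: 0.3 nM

Of these three, compound 1 has the lowest number and is the strongest inhibitor in this assay. Its gaps to the other two lie beyond the usual scatter. The nearest is compound 3 at 0.3 nM, and the furthest is compound 2 at 4.3 nM.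

The next compound to be tested, compound 4 `CC1=C(c2cccc(O)c2)C(c2ccc(OC[C@H](C)N3CCCCCC3)cc2)Oc2ccc(O)cc21`, departs from compound 1 in one place. It has azepan-1-yl in place of piperidin-1-yl on a saturated chain carbon bound to two saturated chain carbons.

Going by the values given here, no two measured compounds differ in one place alone, so the data give no direct measure of what a change of this ring does. Set against compound 1, compound 3 carries a different ring on the same chain and differs elsewhere too, yet compound 3 remains close with 0.3 nM. A small step towards a higher number is therefore expected in this assay, possibly none beyond the scatter. The estimated step is a 2.0-fold higher number from compound 1 to compound 4 (0.30 log units; within the scatter). For compound 4 the estimated value is 0.2 nM, with an expected range from 0.07 nM to 0.7 nM.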

Compound 4, half-maximal inhibitory concentration: 0.2 nM
Estimate against measurement, compound 4: no gap at the digits printed, within the range that was stated.
By their numbers in this assay, from the lowest: compounds 1, 4 and 3 (each within the scatter of the next, the first and the last beyond it); then compound 2.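

In this assay, going by these compounds alone, azepan-1-yl in place of piperidin-1-yl, on a saturated chain carbon bound to two saturated chain carbons, gives a 2.0-fold higher number from compound 1 to compound 4 (0.30 log units; within the scatter) and provides the first comparison in this set of compounds that differ in one place alone. It shows that, at this place and on this core, the seven-membered ring and the six-membered ring cannot be told apart in this assay, so the exchange is tolerated and compound 1 and compound 4 stand level within the scatter. No available evidence bears on why the two rings read alike.

Open questions remain about whether this tolerance extends to a larger ring such as azocan-1-yl, to a ring with a second hetero atom such as morpholin-4-yl, or to an open-chain amine such as dimethylamino. Going by these compounds, it is also open whether the same exchange would read alike on the cores of compound 2 and compound 3, which differ from compound 1 in more than one place.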